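The source may report more compounds than this note shows. Statements on the series, on what has been measured and on what is new or still open speak of the compounds shown alone.

Compound 3 `Nc1ccccc1NC(=O)c1ccc(CSC(=S)N2CCN(c3cnccn3)CC2)cc1` is the reference point for this step. In a functional assay on HeLa cells (Homo sapiens) for antiproliferative activity, read by CCK-8 assay, with a stated time of 72 h, tested at 8 uM (on this read-out lower numbers stand for a weaker effect and higher numbers for a stronger effect at the one concentration tested), compound 3 gives 76.9%, which is the lowest of the three numbers in hand, though it sits within the scatter of both others: compound 2 `Nc1ccccc1NC(=O)c1ccc(CSC(=S)N2CCN(c3ccncc3)CC2)cc1` gives 77.4% and compound 1 `Nc1ccccc1NC(=O)c1ccc(CSC(=S)N2CCN(Cc3cccnc3)CC2)cc1` gives 78% in this assay. The three measured steps are all exchanges of one group on the amine nitrogen in the ring: a number 0.6 percentage points lower from compound 1 to compound 2 (within the scatter), a number 1.1 percentage points lower from compound 1 to compound 3 (within the scatter) and a number 0.5 percentage points lower from compound 2 to compound 3 (within the scatter). None of them moved the read-out beyond the scatter.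

Compound 4 `Nc1ccccc1NC(=O)c1ccc(CSC(=S)N2CCN(Cc3ccccc3)CC2)cc1` differs from compound 3 in the same place: benzyl in place of pyrazin-2-yl on an amine nitrogen in a ring. All three measured steps bear on this change, since each also replaces one aromatic group with another on that ring nitrogen, and each was within the scatter. Among the measured compounds shown here, the benzyl group has no hydrogen-bond acceptors where the groups of compounds 1 to 3 each had some, but the data give no step that tests that feature on its own.

The expectation is therefore a step of no size beyond the scatter in this assay for compound 4, estimated as a number 0.9 percentage points lower from compound 3 to compound 4 (within the scatter). For compound 4 in this assay the estimate is 76%, expected to lie between 63% and 86%.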

Compound 4, a percentage reported as inhibition, at one concentration (the size of the read-out at that concentration, not a potency): 31.3%
Estimate against measurement, compound 4: 44.7 percentage points above, outside the stated range (below it).
By their numbers in this assay, from the lowest: compound 4; then compounds 3, 2 and 1 (each within the scatter of the next).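

In this assay the amine nitrogen in a ring, quiet until now, proves able to carry a large step: benzyl in place of pyrazin-2-yl gives a number 45.6 percentage points lower from compound 3 to compound 4 (beyond the scatter) in this series, and benzyl in place of pyridin-4-yl gives a number 46.1 percentage points lower from compound 2 to compound 4 (beyond the scatter) of nearly the same size. The closest comparison is compound 1 with compound 4, which both keep a saturated chain carbon on that nitrogen, and there phenyl in place of pyridin-3-yl gives a number 46.7 percentage points lower from compound 1 to compound 4 (beyond the scatter) as well, so that chain carbon alone does not set compound 4 apart; among these four compounds, the one whose aromatic ring is of carbon only stands alone, and none goes against that pattern. No measurement at hand accounts for the loss.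

The compounds shown leave open whether a single nitrogen at any ring place is enough, as a pyridin-2-yl group would test, and whether a plain phenyl directly on the ring nitrogen behaves like benzyl. They also leave open how a benzyl carrying a methoxy group or an amine on its ring would read out.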